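Tail amide variation: from compound 3 to compound 4

The compounds below may be only part of what the source reports. "The series", "measured", "known", "first", "only" and "open" are said of these compounds alone.

In a functional assay on H4 cells for agonist activity at growth hormone secretagogue receptor type 1 (Homo sapiens), read by FLIPR (a lower number here means that less compound is needed, a higher number that more compound is needed for the effect), compound 1 `CC(C)(N)C(=O)N[C@H](COCc1ccccc1)c1nnnn1CCCCC#N` gives 35 nM, compound 2 `CC(C)(N)C(=O)N[C@H](COCc1ccccc1)c1nnnn1CC#N` gives 29 nM and compound 3 `CCCCNC(=O)CCn1nnnc1[C@@H](COCc1ccccc1)NC(=O)C(C)(C)N` gives 42 nM. Compound 3 carries the highest of the three numbers, yet its distances are small: a 1.2-fold higher number from compound 1 to compound 3 (0.08 log units; within the scatter) and a 1.4-fold higher number from compound 2 to compound 3 (0.16 log units; within the scatter), both within the scatter, so no order among the three can be read. Compound 4 `CC(C)(N)C(=O)N[C@H](COCc1ccccc1)c1nnnn1CCC(=O)NCc1ccccc1` differs from compound 3 by phenyl in place of propyl on a saturated chain carbon bound to an amide-type nitrogen. Within the data shown here, no measured step touches this position; the steps that alter the chain on the aromatic nitrogen, a 1.2-fold lower number from compound 1 to compound 2 (0.08 log units; within the scatter) included, all stay within the scatter. On that basis the step of a 1.1-fold lower number from compound 3 to compound 4 (0.02 log units; within the scatter) is expected to remain within the scatter as well. Compound 4 is therefore estimated at 40 nM in this assay, with a range from 15 nM to 110 nM.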

Compound 4, half-maximal effective concentration: 51 nM
The estimate for compound 4 lay 1.3-fold (0.11 log units) below the measured number, and the stated range covers the measured number.
By their numbers in this assay, from the lowest: compounds 2, 1, 3 and 4 (each within the scatter of the next).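

In this assay, the change from butylcarbamoyl to benzylcarbamoyl gives a 1.2-fold higher number from compound 3 to compound 4 (0.08 log units; within the scatter) and is the only listed step at this position, so a phenyl in place of propyl on the saturated chain carbon bound to the amide-type nitrogen leaves the number within the scatter. The steps of a 1.8-fold higher number from compound 2 to compound 4 (0.25 log units; within the scatter) and a 1.5-fold higher number from compound 1 to compound 4 (0.16 log units; within the scatter) also stay within it, so the benzylcarbamoyl tail cannot be told apart from either nitrile-ended chain. No supporting data bear on this result. Still open, from the compounds shown here alone, is whether any group here moves the number beyond the scatter, such as an amine or a carboxylic acid in place of benzylcarbamoyl, or a longer chain carrying the phenyl.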